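A few compounds are considered here, and "the series" means these few. Any claim that something is new, unique, unknown or untested is made for them only; others in the source may bear on it.

Notes on the series. Compound 1 `Cc1nnsc1CO/N=C/c1c(C)nn(C)c1Oc1ccccc1Cl` and compound 2 `CCc1nnsc1CO/N=C/c1c(C)nn(C)c1Oc1ccccc1Cl` share one core, while compound 3 `Cc1nnsc1CO/N=C/c1c(C)nn(C)c1Cl` carries a different core. In a functional assay on PANC-1 cells (Homo sapiens) for inhibition, read by MTT assay, with a stated time of 48 h (a higher number here means a weaker inhibitor, a lower number a stronger inhibitor), compound 1 reaches only a limit of the assay, > 50000 nM. Compound 2 likewise reaches only a limit in this assay, > 50000 nM. Compound 3 gives a number in this assay, 26600 nM. The change methyl in place of hydrogen on a saturated chain carbon bound to an aromatic carbon gives the step that the two limits leave unreadable from compound 1 to compound 2, which the limit of > 50000 nM in this assay, at which 2 of the 3 values shown sit, leaves without a readable size. The core change chloro in place of 2-chlorophenoxy on an aromatic carbon gives the step of an at least 1.8-fold lower number from compound 1 to compound 3 (0.27 log units; that floor lies within the scatter).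

Compound 4 `CCc1nnsc1CO/N=C/c1c(C)nn(C)c1Cl` is not yet measured in this assay. Within the data shown here, it differs from compound 3 by methyl in place of hydrogen on a saturated chain carbon bound to an aromatic carbon, the same change as the one between compound 1 and compound 2, made on the core of compound 3; the two cores differ by chloro in place of 2-chlorophenoxy on an aromatic carbon. Since the step that the two limits leave unreadable from compound 1 to compound 2 could not be read, the step from compound 3 to compound 4 is expected to be small, a 1.1-fold higher number from compound 3 to compound 4 (0.05 log units; within the scatter). Compound 4 is accordingly estimated at 30000 nM in this assay, expected between 12000 nM and 60000 nM.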

Compound 4, half-maximal inhibitory concentration: > 50000 nM
Compound 4 gave a limit, no number; the forecaster's own chance of this, stated with the estimate: 30%; at least 1.6-fold (0.22 log units) between middle value and limit.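

On the core of compound 3, methyl in place of hydrogen on a saturated chain carbon bound to an aromatic carbon gives in this assay an at least 1.8-fold higher number from compound 3 to compound 4 (0.27 log units; that floor lies within the scatter), so this floor alone does not establish a real loss. Compound 4 reaches only a limit, > 50000 nM. The same change on the core of compound 1 and the core change between compound 2 and compound 4 cannot be read, so the data neither confirm nor exclude that the change carries from one core to the other, and its size on either core remains unknown because of a single limit: the limit of > 50000 nM in this assay, at which 3 of the 4 values shown sit.

Still open, on these data alone, is how a propyl or longer chain would behave on a saturated chain carbon bound to an aromatic carbon, on either core. Also open, as far as these compounds go, is whether an amine or a carboxylic acid in place of chloro on an aromatic carbon would give a readable number in this assay, where only compound 3 gives one so far, 26600 nM.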